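Replacing pyridin-2-yl with 6-methoxypyridin-3-yl

The source may hold more compounds than are shown below. What is called first, only, known or untested is meant among the compounds shown, and "the series" means these compounds.

Measured in a functional assay on MCF7 cells (Homo sapiens) for antiproliferative activity, read by MTT assay, with a stated time of 24 h (on this read-out higher numbers stand for weaker inhibition and lower numbers for stronger inhibition), as follows
- compound 1 `COC(=O)c1scc(-c2ccc(NC(=O)c3ccccn3)cc2)c1OC` gives 19200 nM
- compound 2 `COC(=O)c1scc(-c2ccc(NC(=O)c3cccc(I)c3)cc2)c1OC` gives 12300 nM
- compound 3 `COC(=O)c1scc(-c2ccc(NC(=O)c3ccc(C#N)nc3)cc2)c1OC` gives 9540 nM

Compound 1 sits within the scatter of both other compounds. Compound 4 `COC(=O)c1scc(-c2ccc(NC(=O)c3ccc(OC)nc3)cc2)c1OC` has 6-methoxypyridin-3-yl in place of pyridin-2-yl on a carbonyl carbon, a change counted as 6-methoxypyridin-3-yl in place of pyridin-2-yl on a carbonyl carbon in full. Two measured swaps at that place bear on this: a 2.0-fold lower number from compound 1 to compound 3 (0.30 log units; within the scatter) with 6-cyanopyridin-3-yl, the closest match, and a 1.6-fold lower number from compound 1 to compound 2 (0.19 log units; within the scatter) with 3-iodophenyl. In this assay a similarly small step towards a lower number is therefore expected, nothing beyond the scatter. The expected change is a 1.6-fold lower number from compound 1 to compound 4 (0.20 log units; within the scatter) as the estimated step. Compound 4 is estimated at 12000 nM and expected between 5500 nM and 24000 nM.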

Compound 4, half-maximal inhibitory concentration: 5250 nM
Beside the measured number, compound 4's estimate is 2.3-fold (0.36 log units) above it; measured number below the stated range.
By their numbers in this assay, from the lowest: compounds 4, 3, 2 and 1 (each within the scatter of the next, the first and the last beyond it).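

In this assay this carbonyl carbon now shows a step that clears the scatter, with a 3.7-fold lower number from compound 1 to compound 4 (0.56 log units; beyond the scatter) and a 2.3-fold lower number from compound 2 to compound 4 (0.37 log units; beyond the scatter) both modest in size. Against 6-cyanopyridin-3-yl the result is less clear, with a 1.8-fold lower number from compound 3 to compound 4 (0.26 log units; within the scatter) still inside the scatter, so methoxy and cyano on an aromatic carbon cannot be told apart here. Nothing available explains the gain. From the compounds shown here alone, whether an amine or an ethoxy group in place of methoxy would lower the number further remains open.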